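Methyl for Phenyl on a Lower-Starting Analogue

This account rests on a few compounds, and the source may have more. Where it says the series, first, only, none or still open, it means among the compounds named here.

Compound 1 `CC/N=C(/NC#N)NCCCn1nc(-c2ccccc2)ccc1=O` gives 62.9% in a functional assay on the whole organism with Rattus norvegicus as the target, at a dose of 100 mg/kg; a lower number here means less inhibition, a higher number more inhibition at the dose given (going by the name of the read-out). Compound 2 `CC/N=C(/NC#N)NCCCn1nc(C)ccc1=O` differs from it by methyl in place of phenyl on an aromatic carbon and gives 34.5% in this assay, a step of a number 28.4 percentage points lower from compound 1 to compound 2 (beyond the scatter). Compound 3 `C/N=C(\S)NCCCCCCn1nc(-c2ccccc2)ccc1=O` has a different core, separated from compound 1 by a group of 8 heavy atoms (5 carbon, 2 nitrogen, 1 sulfur; no ring) in place of a group of 8 heavy atoms (4 carbon, 4 nitrogen; no ring), on a saturated chain carbon, three bonds along the chain from an aromatic nitrogen; in this assay compound 3 gives 22.2%, a step of a number 40.7 percentage points lower from compound 1 to compound 3 (beyond the scatter). Compound 4 `C/N=C(\S)NCCCCCCn1nc(C)ccc1=O` has not been measured; it differs from compound 3 by methyl in place of phenyl on an aromatic carbon, the same change seen between compound 1 and compound 2, at the same place. For compound 4 a fall is expected, yet a smaller one in points, since compound 3 already gives 22.2% and little room remains. The expected step is a number 14.2 percentage points lower from compound 3 to compound 4 (beyond the scatter). Compound 4 is therefore estimated at 8%, between -5% and 22%.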

Compound 4, a percentage reported as inhibition, in the whole organism at one dose (the size of the read-out at that dose, not a potency): -12.5%
For compound 4 the middle estimate is 20.5 percentage points above the measured one, outside the stated range (below it).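

Methyl in place of phenyl on an aromatic carbon gives a step of a number 34.7 percentage points lower from compound 3 to compound 4 (beyond the scatter) in this assay, and this step can be set beside the earlier one on the core of compound 1: the same change on two cores in this assay, a number 28.4 percentage points lower (beyond the scatter) from compound 1 to compound 2 and a number 34.7 percentage points lower (beyond the scatter) from compound 3 to compound 4, 6.3 percentage points apart, within the scatter of two such steps. Across these two cores, then, the change carries over with a similar size in points, and the phenyl compound gives the higher number in both pairs. This does not show why phenyl gives the higher number, and two pairs do not make a rule for the whole series.

As far as these compounds go, whether a cyclohexyl group or an ethyl group on that aromatic carbon would behave like phenyl or like methyl stays open. So does the size of the step on a core carrying an amine at the end of the chain.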